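Replacing 1-aminopropyl with 1-aminocyclopentyl on compound 3

The source may report more compounds than this note shows. Statements on the series, on what has been measured and on what is new or still open speak of the compounds shown alone.

Measured so far in a functional assay on NCI-H1975 cells (Homo sapiens) for antiproliferative activity; on this read-out lower numbers stand for stronger inhibition and higher numbers for weaker inhibition
Compound 1 `Cc1c2c(n3c1CCN(C)C[C@@H](C)[C@H](C)Nc1cc-3ccc1C(N)=O)CC(C)(C)CC2=O` gives 27 nM
Compound 2 `COCCC(=O)N1CCc2c(C)c3c(n2-c2ccc(C(N)=O)c(c2)N[C@@H](C)[C@H](C)C1)CC(C)(C)CC3=O` gives 31 nM
Compound 3 `CC[C@H](N)C(=O)N1CCc2c(C)c3c(n2-c2ccc(C(N)=O)c(c2)N[C@@H](C)[C@H](C)C1)CC(C)(C)CC3=O` gives 41 nM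

Compound 3 stands within the scatter of both other compounds, so these numbers do not rank the three. Compared with compound 3, compound 4 `Cc1c2c(n3c1CCN(C(=O)C1(N)CCCC1)C[C@@H](C)[C@H](C)Nc1cc-3ccc1C(N)=O)CC(C)(C)CC2=O` carries 1-aminocyclopentyl in place of 1-aminopropyl on a carbonyl carbon. The closest measured step also changes the group on such a carbon (a 1.3-fold higher number from compound 2 to compound 3 (0.12 log units; within the scatter)). The two changes on an amine nitrogen in a ring (a 1.1-fold higher number from compound 1 to compound 2 (0.06 log units; within the scatter) and a 1.5-fold higher number from compound 1 to compound 3 (0.18 log units; within the scatter)) also stay within the scatter. Within the data shown here, no measured step brings a ring into this place, which leaves the expectation uncertain. In this assay no step beyond the scatter is expected, in either direction. The estimated step is small (a 1.1-fold lower number from compound 3 to compound 4 (0.03 log units; within the scatter)). For compound 4 the estimated value is 38 nM (expected range 15 nM to 95 nM).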

Compound 4, half-maximal inhibitory concentration: 26 nM
For compound 4 the middle estimate is 1.5-fold (0.16 log units) above the measured one; the measured number falls inside the stated range.
By their numbers in this assay, from the lowest: compounds 4, 1, 2 and 3 (each within the scatter of the next).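

In this assay, among these compounds, a ring enters this place for the first time, on a carbonyl carbon, and 1-aminocyclopentyl in place of 1-aminopropyl stays within the scatter (a 1.6-fold lower number from compound 3 to compound 4 (0.20 log units; within the scatter)). The same holds against 2-methoxyethyl (a 1.2-fold lower number from compound 2 to compound 4 (0.08 log units; within the scatter)) and against the methyl on the amine nitrogen in the ring (a 1.0-fold lower number from compound 1 to compound 4 (0.02 log units; within the scatter)), so this larger acyl group gives no measurable change. No evidence bears on why the numbers stay so close. As far as these compounds go, what a plain cyclopentyl without the amine, or a carboxylic acid, would give here remains open, as does whether any group at this place can move the number beyond the scatter.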